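The compounds below may be only part of what the source reports. "The series", "measured", "known", "first", "only" and "open" are said of these compounds alone.

Compound 1 `O=S(=O)(c1ccc(F)c(F)c1)c1cnc2c(F)cccc2c1-c1ccc(Cl)cc1`: 0.28 mL/min
Compound 2 `COc1ccc(-c2c(S(=O)(=O)c3cc(Cl)cc(Cl)c3)cnc3c(F)cccc23)cc1`: 2.11 mL/min
Compound 3 `COc1cccc(-c2c(S(=O)(=O)c3cc(Cl)cc(Cl)c3)cnc3c(F)cccc23)c1`: 2.31 mL/min

In an ADME assay on microsomes from liver (Homo sapiens) for metabolic stability, tested at 2.5 uM (on this read-out lower numbers stand for slow clearance and higher numbers for fast clearance), compound 3 stands highest of the three numbers, with compound 2 within the scatter of it and compound 1 far lower. Compound 4 `O=S(=O)(c1cc(Cl)cc(Cl)c1)c1cnc2c(F)cccc2c1-c1ccc(Cl)cc1` differs from compound 3 by 4-chlorophenyl in place of 3-methoxyphenyl on an aromatic carbon. Going by the values given here, the only measured step, a 1.1-fold higher number from compound 2 to compound 3 (0.04 log units; within the scatter), concerns where the methoxy group sits and says nothing about exchanging it for 4-chlorophenyl. Compound 1 also carries 4-chlorophenyl and shows the lowest number, yet it differs from compound 4 in a second place as well, so its value cannot be laid to that group alone. Compound 4 is therefore expected near 0.9 mL/min, between 0.3 mL/min and 2.5 mL/min, which means an expected step of a 2.6-fold lower number from compound 3 to compound 4 (0.41 log units; beyond the scatter).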

Compound 4, intrinsic clearance in a liver preparation (reported as CLH), per the amount of preparation that the assay uses: 0.78 mL/min
Compound 4: middle estimate off by 1.2-fold (0.06 log units), on the high side; low and high end bracket the measured number.
By their numbers in this assay, from the lowest: compound 1; then compound 4; then compounds 2 and 3 (each within the scatter of the next).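

In this assay, 4-chlorophenyl in place of 3-methoxyphenyl on the aromatic carbon opposite the ring nitrogen gives a 3.0-fold lower number from compound 3 to compound 4 (0.47 log units; beyond the scatter), and chloro in place of methoxy gives a 2.7-fold lower number from compound 2 to compound 4 (0.43 log units; beyond the scatter), so exchanging the methoxy group moves the number beyond the scatter, which shifting it around the phenyl ring did not. The sulfonyl side matters too: 3,5-dichlorophenyl in place of 3,4-difluorophenyl gives a 2.8-fold higher number from compound 1 to compound 4 (0.44 log units; beyond the scatter). Nothing measured here explains either change. Open remains how an amine or a carboxylic acid on that phenyl ring would compare with chloro and methoxy.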